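This account rests on a few compounds, and the source may have more. Where it says the series, first, only, none or still open, it means among the compounds named here.

Working notes on the triazole series

Two compounds of the series carry a measured value in a functional assay on CCRF-CEM cells (Homo sapiens) for inhibition, read by MTT assay, with a stated time of 2 days, tested at 10 uM; a higher number here means more inhibition at the concentration tested (going by the name of the read-out), a lower number less inhibition. Compound 1, `COc1ccc(OC)c(-c2cn(-c3ccc(O)c(C(=O)Nc4cccc(C(F)(F)F)c4)c3)nn2)c1`, bears an amide on the phenol ring and in this assay compound 1 gives 15%. Compound 2, `COc1ccc(-c2cn(-c3ccc(O)c(C(=O)OCCCc4ccccc4)c3)nn2)cc1`, carries the ester with the three-carbon chain to the phenyl ring instead, and in this assay compound 2 gives 5%. The two numbers lie within the scatter of each other, so no order between compound 1 and compound 2 can be read from them; both show little inhibition at the concentration tested.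

Compound 3, `COc1ccc(OC)c(-c2cn(-c3ccc(O)c(C(=O)OCCCc4ccccc4)c3)nn2)c1`, keeps the ester of compound 2 and differs from it in one place: 2,5-dimethoxyphenyl in place of 4-methoxyphenyl on an aromatic carbon. Compound 1 already holds the same 2,5-dimethoxyphenyl, and the low value of compound 1 in this assay, 15%, gives no sign that this group by itself lifts inhibition.

Within the data shown here, no step between measured compounds is available to size this change. The step from compound 2 to compound 3 in this assay is expected to be a number 5 percentage points higher from compound 2 to compound 3 (within the scatter), that is, nothing beyond the scatter in either direction. Compound 3 is therefore expected to give 10% in this assay, with a range from -5% to 25%.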

Compound 3, a percentage reported as inhibition, at one concentration (the size of the read-out at that concentration, not a potency): 5%
Estimate against measurement, compound 3: 5 percentage points above; low and high end bracket the measured number.
By their numbers in this assay, from the lowest: compounds 2, 3 and 1 (each within the scatter of the next).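

Among these compounds, the step of no change at the digits printed from compound 2 to compound 3 (within the scatter) gives the first reading at this position, on an aromatic carbon of the five-membered aromatic ring with 3 nitrogen: with the ester held fixed, 2,5-dimethoxyphenyl in place of 4-methoxyphenyl does not move the number in this assay beyond the scatter. Among the compounds shown here, compound 3 also provides the first direct comparison on the carbonyl carbon, where 3-phenylpropoxy takes the place of (3-(trifluoromethyl)phenyl)amino with the 2,5-dimethoxyphenyl held fixed, and the step of a number 10 percentage points lower from compound 1 to compound 3 (within the scatter) leaves these two groups unresolved in the same assay. No measurement is at hand that bears on these results.

Going by these compounds, both steps start from compounds showing little inhibition at the concentration tested, so whether either change would matter on a compound with more inhibition remains open. Also open, on these data alone, is what a carboxylic acid or a longer chain in place of 3-phenylpropoxy on the carbonyl carbon, or an amine on the aromatic ring in place of a methoxy group of 2,5-dimethoxyphenyl, would give in this assay.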